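The compounds below may be only part of what the source reports. "The series", "measured", "known", "first", "only" and "open" are said of these compounds alone.

In an ADME assay on MT4 cells (Homo sapiens) for cytotoxicity, read by MTT assay (a higher number here means that more compound is tolerated, a lower number that less compound is tolerated), compound 1 `CC(C)c1c(Cc2c(Cl)cccc2Cl)nc(SCC(=O)c2ccccc2)[nH]c1=O` gives > 56000 nM as a limit. Compound 2 `CC(C)c1c(Cc2c(Cl)cccc2Cl)nc(SCC(=O)c2ccc(F)cc2)[nH]c1=O` gives > 54000 nM as a limit too. Compound 3 `CC(C)c1c(Cc2c(F)cccc2F)nc(SCC(=O)c2ccccc2)[nH]c1=O` differs from compound 1 by 2,6-difluorophenyl in place of 2,6-dichlorophenyl on a saturated chain carbon bound to an aromatic carbon and so reads as 2,6-dichlorobenzyl to 2,6-difluorobenzyl. Among the compounds with values here, the one measured step, fluoro in place of hydrogen on an aromatic carbon, reads a step that the two limits leave unreadable from compound 1 to compound 2 and offers no size to carry over. No change beyond the scatter is therefore expected in this assay and the estimate amounts to a step that the limit leaves unreadable from compound 1 to compound 3 as the expected step. Compound 3 is expected at 60000 nM with a range from 20000 nM to 200000 nM as estimated.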

Compound 3, half-maximal cytotoxic concentration: > 60000 nM
Compound 3: no number, only a limit; the forecaster's own chance of this, stated with the estimate: 70%; the middle value lies on the limit itself.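

Within the data shown here, compound 1 and compound 3 both read only as limits in this assay, and no step between them can be read. The compounds shown leave open where any true half-maximal cytotoxic concentration lies, and whether 2,6-difluorobenzyl in place of 2,6-dichlorobenzyl changes it.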